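Shifting fluorine from 4-fluorophenyl to 3-fluorophenyl

The source may report more compounds than this note shows. Statements on the series, on what has been measured and on what is new or still open speak of the compounds shown alone.

Compound 1 `S=C(NCc1ccccc1)N/N=C/c1ccc2ccccc2n1`: 75700 nM
Compound 2 `S=C(N/N=C/c1ccc2ccccc2n1)Nc1ccc(Cl)cc1`: 97200 nM
Compound 3 `Fc1ccc(NC(=S)N/N=C/c2ccc3ccccc3n2)cc1`: 28500 nM

In a functional assay on HT-29 cells (Homo sapiens) for antiproliferative activity, read by sulforhodamine B assay, with a stated time of 72 h (on this read-out higher numbers stand for weaker inhibition and lower numbers for stronger inhibition), compound 3 has the lowest number of the three, with a 2.7-fold lower number from compound 1 to compound 3 (0.42 log units; beyond the scatter) and a 3.4-fold lower number from compound 2 to compound 3 (0.53 log units; beyond the scatter), while a 1.3-fold higher number from compound 1 to compound 2 (0.11 log units; within the scatter). Compound 4 `Fc1cccc(NC(=S)N/N=C/c2ccc3ccccc3n2)c1` differs from compound 3 only in the change (3-fluorophenyl in place of 4-fluorophenyl on an amide-type nitrogen). Within the data shown here, no measured step moves a substituent around the ring; the steps that exist swap the whole group or the halogen. Both steps reaching compound 3 were modest, so a shift of the fluorine is not expected to move the number beyond the scatter. The step of a 1.1-fold higher number from compound 3 to compound 4 (0.02 log units; within the scatter) is the estimate, placing compound 4 at 30000 nM, within 10000 nM to 90000 nM.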

Compound 4, half-maximal inhibitory concentration: 74700 nM
The estimate for compound 4 lay 2.5-fold (0.40 log units) below the measured number, and the stated range covers the measured number.
By their numbers in this assay, from the lowest: compound 3; then compounds 4, 1 and 2 (each within the scatter of the next).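

In this assay the place of the fluorine on the phenyl ring counts, as a 2.6-fold higher number from compound 3 to compound 4 (0.42 log units; beyond the scatter) shows, although the group keeps the same atoms. The lower number of compound 3 therefore belongs to 4-fluorophenyl and not to fluorine on the ring as such, since 3-fluorophenyl stays level with the other groups, with a 1.3-fold lower number from compound 2 to compound 4 (0.11 log units; within the scatter) and a 1.0-fold lower number from compound 1 to compound 4 (0.01 log units; within the scatter) both within the scatter. Nothing available explains why the two fluorophenyl groups differ.

Left open is whether 3-chlorophenyl would differ from 4-chlorophenyl in the same way. On these data alone, how an amine on the phenyl ring or a longer chain in place of benzyl would compare also remains open.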